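The source may hold more compounds than are shown below. What is called first, only, known or untested is meant among the compounds shown, and "the series" means these compounds.

Working notes on the series. Compound 3 `OC[C@H]1O[C@@H](n2cnc3c(O)ncnc32)C[Se]1` was measured in a functional assay on Vero cells (Chlorocebus sabaeus) for cytotoxicity; a higher number here means a weaker inhibitor, a lower number a stronger inhibitor; there compound 3 gives > 100000 nM, which is a limit of the assay and not a number. Compound 2 `Nc1ncnc2c1ncn2[C@H]1C[Se][C@@H](CO)O1` in this assay gives > 100000 nM, again a limit of the assay. Compound 1 `Nc1ccn([C@H]2C[Se][C@@H](CO)O2)c(=O)n1` in this assay returns > 100000 nM; 100000 nM; > 100000 nM (3 entries). Within the data shown here, the one step with both ends measured, a step that the two limits leave unreadable from compound 2 to compound 3, cannot be read because the limit of > 100000 nM in this assay, at which 2 of the 3 values shown sit, covers both of its ends, and the several entries of compound 1 in this assay, > 100000 nM; 100000 nM; > 100000 nM (3 entries) shows the same picture for compound 1. Compound 3 therefore stands at the limit of this assay, as does every other compound measured here, with no ordering among them.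

Compound 4 `Nc1nc(O)c2ncn([C@H]3C[Se][C@@H](CO)O3)c2n1` differs from compound 3 by amino in place of hydrogen on an aromatic carbon. Among the measured compounds shown here, no measured step bears on this change directly; the only step in the set is unreadable, and nothing has moved off the limit. The expectation for compound 4 in this assay is accordingly no step beyond the scatter, a number no higher from compound 3 to compound 4 (the limit leaves the size open), with the result most probably reported once more as a limit. Compound 4 is estimated at 100000 nM, within the range 50000 nM to 200000 nM.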

Compound 4, half-maximal inhibitory concentration: > 100000 nM
Compound 4 ended at the assay's limit (the forecaster's own chance of this, stated with the estimate: 85%); the middle value lies on the limit itself.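

In this assay compound 4 gives > 100000 nM as a limit of the assay and not a number. Compound 3 sits at the same limit, so no step can be read between compound 3 and compound 4. The compounds shown leave open whether any change on the shared core moves a value in this assay off the limit at all.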